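From piperidin-1-yl to (3-methoxyphenyl)amino on the shared core

The source may hold more compounds than are shown below. What is called first, only, known or untested is meant among the compounds shown, and "the series" means these compounds.

Compound 2 `O=C1C=C(N2CCCCC2)C(=O)c2c1nc1n2[C@H]2OC[C@@H](O)[C@H]2OC1` gives > 8000 nM in a functional assay on MCF7 cells (Homo sapiens) for inhibition, read by sulforhodamine B assay (on this read-out higher numbers stand for weaker inhibition and lower numbers for stronger inhibition), which is a limit and not a number. Compound 1 `COc1ccc(NC2=CC(=O)c3nc4n(c3C2=O)[C@H]2OC[C@@H](O)[C@H]2OC4)cc1` gives 5420 nM in this assay. For the measured compounds named here, the only measured step, an at least 1.4-fold higher number from compound 1 to compound 2 (0.16 log units; that floor lies within the scatter), is a floor within the scatter and fixes no firm size. Compound 3 `COc1cccc(NC2=CC(=O)c3nc4n(c3C2=O)[C@H]2OC[C@@H](O)[C@H]2OC4)c1` carries (3-methoxyphenyl)amino in place of piperidin-1-yl on a double-bonded ring carbon. It shares the core of compound 1 and differs from it in the methoxyphenylamino name alone, (3-methoxyphenyl)amino against (4-methoxyphenyl)amino, so the expectation rests on compound 1 at 5420 nM. A modest move to a lower number is expected in this assay, perhaps not beyond the scatter, as the expected step of an at least 1.6-fold lower number from compound 2 to compound 3 (0.20 log units; that floor lies within the scatter). For compound 3 the estimate is 5000 nM, with an expected range of 2200 nM to 10000 nM.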

Compound 3, half-maximal inhibitory concentration: > 4000 nM
Compound 3 gave a limit, no number; the forecaster's own chance of this, stated with the estimate: 25%; the middle value does not contradict the limit.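

In this assay compound 3 gives > 4000 nM, a limit and not a number. For the compounds shown here, compound 2 gives > 8000 nM, also a limit, so no step to compound 3 from compound 1 or compound 2 can be read. Still open, on these data alone, is how (3-methoxyphenyl)amino compares with (4-methoxyphenyl)amino on the shared core in this assay.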